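Cytotoxicity in the benzimidazole aniline series: methylation of the ring nitrogen

A few compounds are considered here, and "the series" means these few. Any claim that something is new, unique, unknown or untested is made for them only; others in the source may bear on it.

Measured compounds in an ADME assay on MDBK cells (Bos taurus) for cytotoxicity, read by MTT assay, with a stated time of 96 h; a higher number here means that more compound is tolerated, a lower number that less compound is tolerated:
compound 1, `CN1CCN(CC(=O)Nc2ccc(-c3nc4cc(C(F)(F)F)ccc4n3C)cc2)CC1`, gives 44000 nM
compound 2, `Cn1c(-c2ccc(N)cc2)nc2cc(C(F)(F)F)ccc21`, gives 74000 nM
compound 3, `CCC(=O)Nc1ccc(-c2nc3cc(C(F)(F)F)ccc3[nH]2)cc1`, gives a limit of the assay, > 100000 nM

Compound 3 therefore stands at the limit rather than at a number; one of the three values sits there (the limit of > 100000 nM in this assay, at which 1 of the 3 values shown sits). The unmeasured compound 4, `CCC(=O)Nc1ccc(-c2nc3cc(C(F)(F)F)ccc3n2C)cc1`, differs from compound 3 by methyl in place of hydrogen on an aromatic nitrogen.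

Within the data shown here, the only measured step, a 1.7-fold higher number from compound 1 to compound 2 (0.23 log units; within the scatter), concerns the amide nitrogen on the other ring and not the aromatic nitrogen, so no measured step bears directly on this change. Compounds 1 and 2 both carry the methyl on the aromatic nitrogen and give numbers, whereas compound 3 without it gives only a limit; two numbers and one limit are too few to claim a pattern.

Compound 4 is estimated at 90000 nM, with a range from 40000 nM to 200000 nM. The expected step is an at least 1.1-fold lower number from compound 3 to compound 4 (0.04 log units; that floor lies within the scatter), with a real chance that this assay again reports only a limit.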

Compound 4, half-maximal cytotoxic concentration: > 100000 nM
Compound 4: a limit, no number; the forecaster's own chance of this, stated with the estimate: 45%; middle value at least 1.1-fold (0.04 log units) from the limit.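

In this assay compound 4 gives > 100000 nM, a limit of the assay and not a number, so methyl in place of hydrogen on the aromatic nitrogen does not bring the propanoyl amide off the limit. The size of that change cannot be read, because compound 3 and compound 4 both stand at the limit: the limit of > 100000 nM in this assay, at which 2 of the 4 values shown sit. Among the compounds carrying the methyl, propanoyl on the aniline nitrogen gives an at least 1.3-fold higher number from compound 2 to compound 4 (0.13 log units; that floor lies within the scatter), while methyl in place of 4-methylpiperazin-1-yl gives an at least 2.2-fold higher number from compound 1 to compound 4 (0.35 log units; beyond the scatter).

From the compounds shown here alone, whether the methyl changes the value at all stays open until a pair with numbers on both sides is available, such as the partners of compound 1 and compound 2 with hydrogen on the aromatic nitrogen. Ethyl or a longer chain at this nitrogen also remains open.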